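From Ethyl to Isopropyl on a Shared Core

A few compounds are considered here, and "the series" means these few. Any claim that something is new, unique, unknown or untested is made for them only; others in the source may bear on it.

Of the compounds shown here, three have been measured in a functional assay on Raji cells (Homo sapiens); on this read-out lower numbers stand for stronger inhibition and higher numbers for weaker inhibition. Compound 1 `CCCCCCCCc1cn([C@H]2C[C@H](O)[C@@H](CO)O2)c(=O)[nH]c1=O` gives 140 ug/mL. Compound 2 `CCc1cn([C@H]2C[C@@H]3OP(=O)(O)OC[C@H]3O2)c(=O)[nH]c1=O`, built on a different core, reaches only a limit of the assay, > 500 ug/mL. Compound 3 `CCCc1cn([C@H]2C[C@@H]3OP(=O)(O)OC[C@H]3O2)c(=O)[nH]c1=O` likewise reaches only a limit, > 500 ug/mL. The step that the two limits leave unreadable from compound 2 to compound 3 therefore cannot be read, because of the limit of > 500 ug/mL in this assay, at which 2 of the 3 values shown sit.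

Compound 4 `CC(C)c1cn([C@H]2C[C@@H]3OP(=O)(O)OC[C@H]3O2)c(=O)[nH]c1=O` differs from compound 2 by methyl in place of hydrogen on a saturated chain carbon bound to an aromatic carbon and a saturated chain carbon. Only the unreadable step from compound 2 to compound 3 bears on this change, and it leaves the size open. For the measured compounds named here, compound 1 shares no single-point difference with compound 4, so its value shows only that a number can be obtained at all on another core. With both measured neighbours of compound 4 sitting at the limit, the expected outcome is that compound 4 again lands at or beyond that limit. The step that the limit leaves unreadable from compound 2 to compound 4 is expected to stay within the scatter. Compound 4 is estimated at 600 ug/mL, with a range from 300 ug/mL to 2000 ug/mL.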

Compound 4, concentration for 50% inhibition: > 500 ug/mL
Compound 4 ended at the assay's limit (the forecaster's own chance of this, stated with the estimate: 80%); the middle value is on the limit's open side.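

Like compound 2 and compound 3, compound 4 stops at a limit of the assay and gives no number, so no step among these three compounds can be read: (the limit of > 500 ug/mL in this assay, at which 3 of the 4 values shown sit). As far as these compounds go, whether ethyl, propyl and isopropyl differ at all in this assay stays open.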